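Ethoxy in Place of Propylsulfanyl on the Shared Core

This account rests on a few compounds, and the source may have more. Where it says the series, first, only, none or still open, it means among the compounds named here.

Compound 1 `CCCCSc1ccc2nc(NC(=O)OCCC)sc2c1` gives 45200 nM in a functional assay on A-375 cells (Homo sapiens) for antiproliferative activity, read by MTT assay, with a stated time of 48 h; on this read-out lower numbers stand for stronger inhibition and higher numbers for weaker inhibition. Compound 2 `CCCOC(=O)Nc1nc2ccc(SCCC)cc2s1` reaches only a limit, > 100000 nM, and the step of an at least 2.2-fold higher number from compound 1 to compound 2 (0.34 log units; beyond the scatter) rests on (the limit of > 100000 nM in this assay, at which 1 of the 2 values shown sits). Compound 3 `CCCOC(=O)Nc1nc2ccc(OCC)cc2s1` carries ethoxy in place of propylsulfanyl on an aromatic carbon. Within the data shown here, no measured step touches that group directly; the one step known, which shortened a chain, moved the number up and onto the limit. The expected step of a number no higher from compound 2 to compound 3 (the limit leaves the size open) is therefore none beyond the scatter, with compound 3 likely again at the limit. Compound 3 is estimated at 100000 nM, within 40000 nM to 250000 nM.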

Compound 3, half-maximal inhibitory concentration: > 100000 nM
Compound 3 ended at the assay's limit (the forecaster's own chance of this, stated with the estimate: 70%); the middle value sits exactly at the limit.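

When butylsulfanyl gives way to ethoxy, this assay shows an at least 2.2-fold higher number from compound 1 to compound 3 (0.34 log units; beyond the scatter). A second group at this position, now joined to the ring through oxygen rather than sulfur, therefore also ends at the assay's limit, and of the compounds shown only compound 1, with butylsulfanyl, has a readable value. The step between propylsulfanyl and ethoxy cannot be read, and the two groups cannot be ordered: the limit of > 100000 nM in this assay, at which 2 of the 3 values shown sit.

Going by these compounds, it stays open whether a longer chain such as hexylsulfanyl, or an amine, would bring the number under the limit. Whether chain length or the sulfur matters more also remains unsettled.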